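The source may report more compounds than this note shows. Statements on the series, on what has been measured and on what is new or still open speak of the compounds shown alone.

Measured compounds:
- compound 1 `O=C(NC1CCCCC1)NS(=O)(=O)c1ccc(-n2nc(-c3ccccc3)ccc2=O)cc1`: 86.2%
- compound 2 `Cc1ccc(-c2ccc(=O)n(-c3ccc(S(=O)(=O)NC(=O)NC4CCCCC4)cc3)n2)cc1`: 110%
- compound 3 `O=C(NC1CCCCC1)NS(=O)(=O)c1ccc(-n2nc(-c3ccc(Cl)cc3)ccc2=O)cc1`: 114%

In a functional assay on the whole organism (blood, strain Wistar albino) for inhibition, with Rattus norvegicus as the target, read by colorimetric assay, with stated times of 15 min and 90 min, at a dose of 20 mg/kg by the oral route (on this read-out lower numbers stand for less inhibition and higher numbers for more inhibition at the one dose given (going by the name of the read-out)), compound 3 gives the top number of the three. Its gap to compound 1 is beyond the scatter a number 27.8 percentage points higher from compound 1 to compound 3 (beyond the scatter), while compound 2 and compound 3 lie within the scatter of each other a number 4 percentage points higher from compound 2 to compound 3 (within the scatter), so no order between those two can be read.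

Compound 4 `Cc1cc(-c2ccc(=O)n(-c3ccc(S(=O)(=O)NC(=O)NC4CCCCC4)cc3)n2)ccc1Cl` is the next step from compound 3. The change is methyl in place of hydrogen on an aromatic carbon.

Going by the values given here, one measured step bears on adding a methyl to an aromatic carbon: from compound 1 to compound 2 the number rose by a number 23.8 percentage points higher from compound 1 to compound 2 (beyond the scatter), a modest gain beyond the scatter. That methyl, however, entered a ring that carried no other substituent, whereas in compound 4 it enters ortho to a chloro group already present, and compound 3 already gives 114%, a number with little room left on this read-out. A second methyl-for-hydrogen step on a chloro-bearing ring has not been measured. On this basis no step beyond the scatter is expected; the expected step is a number 2 percentage points lower from compound 3 to compound 4 (within the scatter). Compound 4 is estimated at 112%, within a range of 98% to 126%.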

Compound 4, a percentage reported as inhibition, in the whole organism at one dose (the size of the read-out at that dose, not a potency): 55.2%
Estimate against measurement, compound 4: 56.8 percentage points above; measured number below the stated range.
By their numbers in this assay, from the lowest: compound 4; then compound 1; then compounds 2 and 3 (each within the scatter of the next).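

In this assay the outcome of a methyl on an aromatic carbon is not the same on every ring of this series, and this pair of steps is the first to show it: the same change on two cores in this assay, a number 23.8 percentage points higher (beyond the scatter) from compound 1 to compound 2 and a number 58.8 percentage points lower (beyond the scatter) from compound 3 to compound 4, 82.6 percentage points apart, beyond the scatter of two such steps

Ortho to a chloro group, the methyl gives a large loss, a number 58.8 percentage points lower from compound 3 to compound 4 (beyond the scatter), so a chloro and a methyl that each go with high numbers when alone on the ring do not keep those numbers when they stand together. The 4-chloro-3-methylphenyl group also falls short of the 4-methylphenyl group, a number 54.8 percentage points lower from compound 2 to compound 4 (beyond the scatter), and even of the bare phenyl, a number 31 percentage points lower from compound 1 to compound 4 (beyond the scatter), so the change takes the number below that of the unsubstituted ring rather than merely cancelling the gain from the chloro group.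

The compounds shown leave open whether the loss belongs to a methyl at this place alone or to its pairing with the chloro group, and whether a methoxy, a fluoro or a hydroxymethyl group there would behave alike. With a single dose on a single read-out, they also leave open how compound 4 would stand at other doses.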